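From isopropyl to sec-butyl: an estimate for compound 4

The source may report more compounds than this note shows. Statements on the series, on what has been measured and on what is new or still open speak of the compounds shown alone.

Measured so far in a functional assay on L1210 cells (Mus musculus) (a higher number here means a weaker inhibitor, a lower number a stronger inhibitor), as follows:
compound 1 (`CCCNC(=O)Nc1ccc(C(C)C)cc1`) gives 14000 nM
compound 2 (`CNC(=O)Nc1ccc(C(C)C)cc1`) gives 135000 nM
compound 3 (`CCNC(=O)Nc1ccc(C(C)C)cc1`) gives 35000 nM

Compound 3 stands in the middle of the three, with the second highest number at 35000 nM in this set. Compound 4 (`CCNC(=O)Nc1ccc(C(C)CC)cc1`) differs from it by methyl in place of hydrogen on a saturated chain carbon, two bonds along the chain from an aromatic carbon in one place: methyl in place of hydrogen on a saturated chain carbon, two bonds along the chain from an aromatic carbon, which turns isopropyl into sec-butyl.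

Among the measured compounds shown here, all the measured steps lie elsewhere, on the chain at the amide-type nitrogen. On that chain, a 3.9-fold lower number from compound 2 to compound 3 (0.59 log units; beyond the scatter) came with an added methyl, while shortening gave a 2.5-fold higher number from compound 1 to compound 3 (0.40 log units; beyond the scatter) in one stage and a 9.6-fold higher number from compound 1 to compound 2 (0.98 log units; beyond the scatter) in two. Across these three compounds a longer chain goes with a lower number, and none goes against this. For the measured compounds named here, no measured pair alters the isopropyl group, so these steps are only an indirect guide. A modest move toward a lower number is expected, and the estimate means a 1.8-fold lower number from compound 3 to compound 4 (0.24 log units; within the scatter) in this assay here. For compound 4 the estimated value is 20000 nM (expected range from 9000 nM to 42000 nM).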

Compound 4, half-maximal inhibitory concentration: 43000 nM
Estimate against measurement, compound 4: 2.2-fold (0.33 log units) below; measured number outside the range, above it.
By their numbers in this assay, from the lowest: compound 1; then compounds 3 and 4 (each within the scatter of the next); then compound 2.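

In this assay, the first measured change away from the chain at the amide-type nitrogen, isopropyl to sec-butyl, gives a 1.2-fold higher number from compound 3 to compound 4 (0.09 log units; within the scatter), so compound 3 and compound 4 cannot be told apart. At the saturated chain carbon, two bonds along the chain from an aromatic carbon, this single methyl in place of hydrogen therefore leaves no effect that can be read in this assay, whereas the same kind of exchange on the chain at the amide-type nitrogen gave a 3.9-fold lower number from compound 2 to compound 3 (0.59 log units; beyond the scatter), which lies beyond the scatter, so the link between chain length and number seen there does not extend to this position on the evidence of this one pair. No accompanying measurement bears on this result, and the reading rests on the numbers alone.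

What the compounds shown leave open is whether a larger change at this place, such as a longer chain, a phenyl ring or a hydroxyl or carboxylic acid group on the sec-butyl chain, would move the number beyond the scatter. Going by these compounds, it also remains open whether sec-butyl would behave in the same way with the propyl chain of compound 1 at the amide-type nitrogen.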